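The source may hold more compounds than are shown below. What is called first, only, known or untested is meant among the compounds shown, and "the series" means these compounds.

Compound 1, `Cc1ccc(C(=O)CCN2CCN(c3ccc(C(F)(F)F)cc3)CC2)cc1`, in an ADME assay on Vero cells (Chlorocebus sabaeus) for cytotoxicity, read by resazurin assay, with a stated time of 72 h (a higher number here means a weaker inhibitor, a lower number a stronger inhibitor), gives 140000 nM.
Compound 2, `Cc1ccc(C(=O)CCN2CCN(c3ccc(Cl)cc3)CC2)cc1`, in this assay gives 184000 nM.
Compound 3, `COc1ccc(C(=O)CCN2CCN(c3ccc(C(F)(F)F)cc3)CC2)cc1OC`, in this assay gives 243000 nM.

Two of these three compounds differ from compound 1 in one place each. The change chloro in place of trifluoromethyl on an aromatic carbon is made by going from compound 1 to compound 2, and it reads a 1.3-fold higher number from compound 1 to compound 2 (0.12 log units; within the scatter). The change 3,4-dimethoxyphenyl in place of 4-methylphenyl on a carbonyl carbon is made by going from compound 1 to compound 3, and it reads a 1.7-fold higher number from compound 1 to compound 3 (0.24 log units; within the scatter). Neither of these steps leaves the usual scatter of the measurement, so the three numbers are best read as lying close together.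

Compound 4, `COc1ccc(C(=O)CCN2CCN(c3ccc(Cl)cc3)CC2)cc1OC`, has not been measured. It differs from compound 3 by chloro in place of trifluoromethyl on an aromatic carbon. For the measured compounds named here, this is the same change as the one from compound 1 to compound 2, and it sits at the same kind of place in both pairs; what differs between the two pairs is the core, which is described by 3,4-dimethoxyphenyl in place of 4-methylphenyl on a carbonyl carbon. Going by the values given here, the step from compound 3 to compound 4 is therefore expected to be a 1.3-fold higher number from compound 3 to compound 4 (0.11 log units; within the scatter), and that expectation rests on the measured 1.3-fold higher number from compound 1 to compound 2 (0.12 log units; within the scatter), which is the only instance of this change in hand and which stayed within the scatter. Compound 4 is accordingly estimated to give 316000 nM, with a likely range from 180000 nM to 560000 nM.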

Compound 4, half-maximal inhibitory concentration: 185000 nM
Estimate against measurement, compound 4: 1.7-fold (0.23 log units) above; measured number inside the range.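

In this assay, chloro in place of trifluoromethyl on the core of compound 3 reads a 1.3-fold lower number from compound 3 to compound 4 (0.12 log units; within the scatter), and set beside the earlier instance of the same change, the two steps do not differ beyond the scatter: the same change on two cores in this assay, a 1.3-fold higher number (0.12 log units; within the scatter) from compound 1 to compound 2 and a 1.3-fold lower number (0.12 log units; within the scatter) from compound 3 to compound 4, 1.7-fold (0.24 log units) apart, within the scatter of two such steps

This shows that, on both the 4-methylphenyl and the 3,4-dimethoxyphenyl cores, the exchange of 4-(trifluoromethyl)phenyl for 4-chlorophenyl stays within the scatter, so on these two cores it can be carried across as a change that leaves the reading unresolved from that of its partner. It does not show that the change has a real effect of a fixed size or direction, since the opposite signs of the two steps cannot be told from scatter, and because neither step stands clear of the scatter, this pair of cores offers no test of whether a sizeable effect would transfer.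

What the compounds shown leave open is whether a nitrile, an amine or a carboxylic acid in the place of the chloro would also stay within the scatter in this assay. Also open, as far as these compounds go, is whether the same exchange would hold on a core with a longer chain leading from the carbonyl, or on a phenyl carrying a hydroxyl group.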